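The source may hold more compounds than are shown below. What is called first, only, known or untested is meant among the compounds shown, and "the series" means these compounds.

Compound 1 `COc1ccc(/C=C2\N=C(c3ccc(C)cc3)N(C(=O)c3nc4c(c(C)nn4-c4ccccc4)c(=O)[nH]3)NC2=O)cc1` serves as the starting point. In a functional assay on MCF7 cells (Homo sapiens) for cytotoxicity, read by MTT assay, with a stated time of 48 h (on this read-out higher numbers stand for weaker inhibition and lower numbers for stronger inhibition), compound 1 gives 17.3 nM. Compound 2 `Cc1nn(-c2ccccc2)c2nc(C(=O)N3NC(=O)/C(=C/c4ccc(Cl)cc4)N=C3c3ccc(Cl)cc3)[nH]c(=O)c12` gives 17.8 nM, a number within the scatter of that of compound 1, so the two sit together at the strong end of the three numbers, while compound 3 `Cc1ccc(C2=N/C(=C\c3ccccc3)C(=O)NN2C(=O)c2nc3c(c(C)nn3-c3ccccc3)c(=O)[nH]2)cc1` gives 127 nM, clearly further out. Compound 4 `COc1ccc(/C=C2\N=C(c3ccccc3)N(C(=O)c3nc4c(c(C)nn4-c4ccccc4)c(=O)[nH]3)NC2=O)cc1` differs from compound 1 by hydrogen in place of methyl on an aromatic carbon. Within the data shown here, no measured step removes exactly this methyl. Among the measured compounds shown here, the one single change measured, a 7.3-fold higher number from compound 1 to compound 3 (0.87 log units; beyond the scatter), takes away a methoxy elsewhere in the molecule and weakens inhibition. A smaller loss is therefore expected here, though the analogy is loose. Compound 4 is expected to give about 40 nM, with a range from 15 nM to 120 nM. This corresponds to an expected step of a 2.3-fold higher number from compound 1 to compound 4 (0.36 log units; beyond the scatter).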

Compound 4, half-maximal inhibitory concentration: 61.3 nM
Beside the measured number, compound 4's estimate is 1.5-fold (0.19 log units) below it; measured number inside the range.
By their numbers in this assay, from the lowest: compounds 1 and 2 (each within the scatter of the next); then compound 4; then compound 3.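

Removing this single methyl is enough to weaken inhibition: going from 4-methylphenyl to phenyl gives a 3.5-fold higher number from compound 1 to compound 4 (0.55 log units; beyond the scatter) in this assay. Among these compounds, this is the first measured change at this position on the ring, and it shows that the number here responds to the loss of just one carbon. Nothing measured here explains why the methyl matters.

Still open, on these data alone, is what an ethyl chain, an amine or a carboxylic acid would do in the same place, and whether any of them would give stronger inhibition than methyl.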